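This account rests on a few compounds, and the source may have more. Where it says the series, first, only, none or still open, it means among the compounds named here.

Compound 3 `O=C(Nc1cc(Sc2ncn[nH]2)c(O)c2ccccc12)c1cccc(Cl)c1` carries a carboxamide on the shared core. In a functional assay on MDA-MB-231 cells (Homo sapiens) for antiproliferative activity, read by MTT assay, with a stated time of 48 h (a lower number here means a stronger inhibitor, a higher number a weaker inhibitor), compound 3 gives > 100000 nM, which is a limit of the assay rather than a number. Compound 1 `O=C(Nc1cc(Sc2ncn[nH]2)c(O)c2ccccc12)c1ccc([N+](=O)[O-])cc1` gives > 100000 nM in this assay, also a limit. Compound 2 `Cc1nnc(Sc2cc(NC(=O)c3ccc(Cl)cc3)c3ccccc3c2O)s1` gives > 100000 nM in this assay, again a limit. The step that the two limits leave unreadable from compound 1 to compound 3 cannot be sized from two limits. Compound 4 `COc1cccc(C(=O)Nc2cc(Sc3ncn[nH]3)c(O)c3ccccc23)c1` differs from compound 3 by methoxy in place of chloro on an aromatic carbon. Within the data shown here, no measured step covers this exchange; the only guidance is the limit of > 100000 nM in this assay, at which 3 of the 3 values shown sit, so neither direction nor size can be read from the data. Compound 4 is expected to give 150000 nM, with a range from 30000 nM to 600000 nM. That estimate means an expected step that the limit leaves unreadable from compound 3 to compound 4, no more than the scatter.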

Compound 4, half-maximal inhibitory concentration: > 100000 nM
Compound 4: a limit, no number; the forecaster's own chance of this, stated with the estimate: 80%; the middle value is on the limit's open side.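

Among these compounds, compound 4 gives > 100000 nM in this assay, a limit and not a number, and no step to compound 4 from compound 1 or compound 3 can be read. The compounds shown leave open how strongly any of them acts, and which change on the shared core would yield a readable value: the limit of > 100000 nM in this assay, at which 4 of the 4 values shown sit.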